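Adding a Second Fluorine to the Ring of Compound 3

A few compounds are considered here, and "the series" means these few. Any claim that something is new, unique, unknown or untested is made for them only; others in the source may bear on it.

Compound 1 `Cc1cc(=O)n(-c2ccccc2C(F)(F)F)nc1C(=O)Nc1ccc(Oc2ncnc3ccsc23)cc1` and compound 2 `Cc1cc(=O)n(-c2ccccc2C(F)(F)F)nc1C(=O)Nc1ccc(Oc2ncnc3ccsc23)c(F)c1` share one core and were both tested in a functional assay on MCF7 cells (Homo sapiens) for cytotoxicity, read by MTT assay, with a stated time of 72 h; on this read-out lower numbers stand for stronger inhibition and higher numbers for weaker inhibition. In that test compound 1 gives 5550 nM, while compound 2 gives 6020 nM. The change between them is fluoro in place of hydrogen on an aromatic carbon, and it produced a 1.1-fold higher number from compound 1 to compound 2 (0.04 log units; within the scatter).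

Compound 3 `Cc1cc(=O)n(-c2ccc(F)cc2)nc1C(=O)Nc1ccc(Oc2ncnc3sccc23)cc1` rests on another core; the difference between the two cores is not broken down here. In this assay compound 3 gives 21000 nM.

Compound 4 `Cc1cc(=O)n(-c2ccc(F)c(F)c2)nc1C(=O)Nc1ccc(Oc2ncnc3sccc23)cc1` has not yet been measured. It differs from compound 3 by fluoro in place of hydrogen on an aromatic carbon. Among the measured compounds shown here, this is the same kind of change as the one between compound 1 and compound 2, though not the same: in compound 2 the entering fluoro is ortho to a large group and meta to a large group, whereas in compound 4 it is ortho to a fluoro group and meta to a large group. A step of similar small size is expected here, a 1.0-fold higher number from compound 3 to compound 4 (0.02 log units; within the scatter), because the shared change gave a 1.1-fold higher number from compound 1 to compound 2 (0.04 log units; within the scatter). Compound 4 is therefore estimated at 22000 nM, expected to fall between 10000 nM and 48000 nM.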

Compound 4, half-maximal inhibitory concentration: 16100 nM
Compound 4: the middle estimate sits 1.4-fold (0.14 log units) above what was measured; the measured number falls inside the stated range.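

In this assay, the added fluoro gave a 1.3-fold lower number from compound 3 to compound 4 (0.12 log units; within the scatter), so going from 4-fluorophenyl to 3,4-difluorophenyl left the number essentially where it was. The step on the core of compound 1 was similarly small, and the two steps cannot be told apart: the same change on two cores in this assay, a 1.1-fold higher number (0.04 log units; within the scatter) from compound 1 to compound 2 and a 1.3-fold lower number (0.12 log units; within the scatter) from compound 3 to compound 4, 1.4-fold (0.15 log units) apart, within the scatter of two such steps

Among the compounds shown here, this shows that in these two pairs the change had no effect that can be resolved on either core, but it does not show that the change carries over in general: there are only two pairs, neither step has a direction that can be trusted, and the entering fluoro is ortho to a fluoro group only in compound 4.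

Going by these compounds, it remains open whether an amine, a methoxy group or a carboxylic acid in that place would give a step beyond the scatter on either core. On these data alone, it is also open whether fluoro would stay as silent on a core other than these two.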